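The compounds below may be only part of what the source reports. "The series", "measured", "known", "first", "only" and "open" are said of these compounds alone.

Compounds measured in an assay on isolated protein for inhibition of Fatty-acid amide hydrolase 1 (Homo sapiens); a lower number here means a stronger inhibitor, a higher number a weaker inhibitor:

compound 1 `CCCCCCCC/C=C\CCCCCCC(=O)c1ccccc1`, > 100000 nM
compound 2 `CCCCCCCC/C=C\CCCCCCC(=O)c1ncc(-c2ccccn2)o1`, 18 nM
compound 3 `CCCCCCCCCCCCCCCCCC(=O)C(F)(F)F`, 240 nM

Compound 1 gives in this assay only a limit, > 100000 nM, and no number; it stands at the limit of > 100000 nM in this assay, at which 1 of the 3 values shown sits. Compound 2, which keeps the same long chain but carries an oxazole bearing a pyridyl group on the carbonyl carbon, gives 18 nM. Compound 3, a trifluoromethyl ketone with a saturated chain, gives 240 nM. Compounds 2 and 3 are both measured as numbers, and on the figures shown compound 2 sits lower than compound 3.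

Compound 4 `CCCCCCCC/C=C\CCCCCCC(=O)c1nccn1C` has not yet been measured in this assay. Its structure is reached from compound 1 by 1-methyl-1H-imidazol-2-yl in place of phenyl on a carbonyl carbon. The two ring systems on the carbonyl carbon of compounds 2 and 4 share the feature that both are five-membered aromatic rings with hetero atoms, whereas compound 1 carries a carbon-only ring there and gives only a limit.

The step from compound 1 to compound 4 in this assay is expected to be large, toward stronger inhibition, an at least 33-fold lower number from compound 1 to compound 4 (1.52 log units; beyond the scatter). Compound 4 is estimated to give 3000 nM, within a range from 500 nM to 30000 nM.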

Compound 4, inhibition constant: > 100000 nM
Compound 4 was reported as a limit; the forecaster's own chance of this, stated with the estimate: 10%; middle value at least 33-fold (1.52 log units) from the limit.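

No step from compound 1 to compound 4 can be read, because both compounds stand only as limits and not as numbers: the limit of > 100000 nM in this assay, at which 2 of the 4 values shown sit.

The compounds shown leave open whether 1-methyl-1H-imidazol-2-yl in place of phenyl on a carbonyl carbon changes inhibition at all, and in which direction.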